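Phenyl in place of 1H-indol-3-yl: what to expect

The compounds below may be only part of what the source reports. "The series", "measured", "known", "first", "only" and "open" are said of these compounds alone.

In a functional assay on MCF7 cells (Homo sapiens) for cytotoxicity, read by MTT assay, with a stated time of 72 h (a higher number here means a weaker inhibitor, a lower number a stronger inhibitor), compound 1 (`COc1ccc(C=C2C(=O)N(c3ccc(Cl)cc3)N(c3ccc(Cl)cc3)C2=O)cc1OC`) is reported only as a limit, > 128000 nM. Compound 2 (`O=C1C(=Cc2ccco2)C(=O)N(c2ccc(Cl)cc2)N1c1ccc(Cl)cc1`) gives 20300 nM and compound 3 (`O=C1C(=Cc2c[nH]c3ccccc23)C(=O)N(c2ccc(Cl)cc2)N1c1ccc(Cl)cc1`) gives 34200 nM, so compound 3 stands level with compound 2 within the scatter, with a 1.7-fold higher number from compound 2 to compound 3 (0.23 log units; within the scatter).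

Compound 4 (`O=C1C(=Cc2ccccc2)C(=O)N(c2ccc(Cl)cc2)N1c1ccc(Cl)cc1`) carries phenyl in place of 1H-indol-3-yl on a double-bonded chain carbon bound to a double-bonded ring carbon. For the measured compounds named here, no measured step makes this exact change, but three steps at the same place bear on it. The exchange of furan-2-yl and 1H-indol-3-yl was small, whereas the two steps away from 3,4-dimethoxyphenyl were larger: an at least 6.3-fold lower number from compound 1 to compound 2 (0.79 log units; beyond the scatter) and an at least 3.7-fold lower number from compound 1 to compound 3 (0.57 log units; beyond the scatter), both beyond the scatter. In this assay no clear step is therefore expected, though a somewhat higher number seems more likely than a lower one. The estimated step is a 1.3-fold higher number from compound 3 to compound 4 (0.12 log units; within the scatter). For compound 4 the expected value is 45000 nM, with an estimated range of 16000 nM to 128000 nM.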

Compound 4, half-maximal inhibitory concentration: 20200 nM
Compound 4: the middle estimate sits 2.2-fold (0.35 log units) above what was measured; the range from low to high includes it.
By their numbers in this assay, from the lowest: compounds 4, 2 and 3 (each within the scatter of the next). At a limit, above all of these: compound 1.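

Replacing 1H-indol-3-yl with phenyl gives a 1.7-fold lower number from compound 3 to compound 4 (0.23 log units; within the scatter), and replacing furan-2-yl with phenyl gives a 1.0-fold lower number from compound 2 to compound 4 (0.00 log units; within the scatter), so in this assay the three groups cannot be told apart at this place. Plain phenyl also gives an at least 6.3-fold lower number from compound 1 to compound 4 (0.80 log units; beyond the scatter), which shows that a six-membered aromatic ring of carbon only does not by itself set compound 1 apart, and that among the four compounds the 3,4-dimethoxyphenyl group alone stands out. Compound 1 is known only as a limit, so the full size of that step stays unknown: the limit of > 128000 nM in this assay, at which 1 of the 4 values shown sits.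

On these data alone, whether a phenyl bearing a single methoxy group would side with compound 1 or with compound 4 remains open. So does whether an amine or a carboxylic acid on the phenyl would move the number beyond the scatter.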